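The source may report more compounds than this note shows. Statements on the series, on what has been measured and on what is new or still open speak of the compounds shown alone.

Going by the values given here, compound 1 `CO/N=C(\C)c1ccc(Sc2cc(F)cc(C3CCOCC3)c2)cc1` holds the lowest of the two numbers measured so far: in a functional assay (blood) for inhibition, with Homo sapiens as the target (on this read-out higher numbers stand for weaker inhibition and lower numbers for stronger inhibition), compound 1 gives 110 nM. Among the compounds with values here, its only measured neighbour is compound 2 `CN(C)/C(=N\O)c1ccc(Sc2cc(F)cc(C3CCOCC3)c2)cc1`, which carries a different group on the same aromatic carbon; in this assay compound 2 gives 280 nM. Within the data shown here, the single measured step, a 2.5-fold higher number from compound 1 to compound 2 (0.41 log units; beyond the scatter), is the whole of what is known about how changes in this part of the shared core move the number.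

Compound 3 `COC(=O)C(C)(C)CO/N=C(\C)c1ccc(Sc2cc(F)cc(C3CCOCC3)c2)cc1` differs from compound 1 by 1-(methoxycarbonyl)-1-methylethyl in place of hydrogen on a saturated chain carbon bound to an oxygen on an unsaturated carbon. Among the measured compounds shown here, this change sits one bond further out than the one measured step, on the chain rather than on the aromatic carbon, so no measured step bears on it directly. The step of a 2.5-fold higher number from compound 1 to compound 2 (0.41 log units; beyond the scatter) shows only that altering this side of the core has so far moved the number modestly. On that thin basis the expected step of a 2.0-fold higher number from compound 1 to compound 3 (0.30 log units; within the scatter) is small, if any, toward a weaker number. Compound 3 is therefore estimated to give about 220 nM in this assay, within 70 nM to 700 nM.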

Compound 3, half-maximal inhibitory concentration: 420 nM
The estimate for compound 3 lay 1.9-fold (0.28 log units) below the measured number, within the range that was stated.
By their numbers in this assay, from the lowest: compound 1; then compounds 2 and 3 (each within the scatter of the next).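

Going by these compounds alone, replacing a hydrogen on the saturated chain carbon bound to the oxygen with 1-(methoxycarbonyl)-1-methylethyl, which turns the methoxy of compound 1 into 2-(methoxycarbonyl)-2-methylpropoxy, gives the first measured change at this place: in this assay the step is a 3.8-fold higher number from compound 1 to compound 3 (0.58 log units; beyond the scatter). The position therefore responds to substitution, and the higher number means weaker inhibition, yet a group with no ring still leaves the step modest rather than large. No measurement at hand explains why the number rises with this change.

With only this one group at this place, the compounds shown leave open how much of the step belongs to the methyl ester and how much to the branched chain that carries it. A carboxylic acid in place of the ester, an amine at the end of the chain, or a plain ethyl on the oxygen would each help to separate those parts, and whether any group here could bring the number lower than that of compound 1 remains an open question.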